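The source may hold more compounds than are shown below. What is called first, only, known or untested is meant among the compounds shown, and "the series" means these compounds.

Measured in a functional assay on HeLa cells (Homo sapiens) for cytotoxicity, read by MTT assay, with a stated time of 72 h; a higher number here means a weaker inhibitor, a lower number a stronger inhibitor:
- Compound 1 `Cn1ccc2c(Oc3ccc(NC(=O)c4cc5cccnc5n(-c5ccc(Cl)cc5)c4=O)cc3)ncnc21`: 49900 nM
- Compound 2 `Cn1ccc2c(Oc3ccc(NC(=O)c4cc5cccnc5n(-c5ccc(Br)cc5)c4=O)cc3)ncnc21`: 43800 nM
- Compound 3 `Cn1ccc2c(Oc3ccc(NC(=O)c4cc5cccnc5n(-c5ccc(C(F)(F)F)cc5Cl)c4=O)cc3)ncnc21`: 174000 nM

Compound 2, at 43800 nM, sits at the low end of these numbers, level with compound 1 within the scatter. Compound 4 `Cn1ccc2c(Oc3ccc(NC(=O)c4cc5cccnc5n(-c5ccc(Br)cc5)c4=O)cc3F)ncnc21` differs from compound 2 in one place: fluoro in place of hydrogen on an aromatic carbon.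

Among the measured compounds shown here, no measured step touches this ring, so the evidence is indirect. Bromo in place of chloro gave a 1.1-fold lower number from compound 1 to compound 2 (0.06 log units; within the scatter). Only the change to 2-chloro-4-(trifluoromethyl)phenyl on the aromatic nitrogen moved the number beyond the scatter, with a 3.5-fold higher number from compound 1 to compound 3 (0.54 log units; beyond the scatter) and a 4.0-fold higher number from compound 2 to compound 3 (0.60 log units; beyond the scatter), and both steps were modest. For the measured compounds named here, with so small an addition and no direct precedent, no shift beyond the scatter is expected in this assay, and no direction is favoured. The expected change is a 1.1-fold lower number from compound 2 to compound 4 (0.04 log units; within the scatter). Compound 4 is estimated at 40000 nM, with an expected range of 15000 nM to 100000 nM.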

Compound 4, half-maximal inhibitory concentration: 33800 nM
Compound 4: middle estimate off by 1.2-fold (0.07 log units), on the high side; low and high end bracket the measured number.
By their numbers in this assay, from the lowest: compounds 4, 2 and 1 (each within the scatter of the next); then compound 3.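

Among the compounds shown here, the earlier compounds differed only in the group on the aromatic nitrogen, so compound 4 gives the first reading for the six-membered aromatic ring of carbon only. In this assay, fluoro in place of hydrogen on an aromatic carbon of that ring, ortho to a large group and meta to a large group, gives a 1.3-fold lower number from compound 2 to compound 4 (0.11 log units; within the scatter), so this single addition leaves the number within the scatter. Nothing available accounts for this result.

As far as these compounds go, whether a chloro, a methoxy group or an amine on the same carbon would also stay within the scatter remains open. So does whether fluoro on this ring would give a similar result alongside the 2-chloro-4-(trifluoromethyl)phenyl group of compound 3.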